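Third methoxy on the aryl group: expected outcome

The source may report more compounds than this note shows. Statements on the series, on what has been measured and on what is new or still open speak of the compounds shown alone.

Measured so far:
compound 1 `Cc1cc(O)c(C2=NN(c3ccc(S(N)(=O)=O)cc3)C(c3ccccc3Cl)C2)cc1Cl`: 6770 nM
compound 2 `COc1ccc(C2CC(c3cc(Cl)c(C)cc3O)=NN2c2ccc(S(N)(=O)=O)cc2)cc1OC`: 77500 nM

Among the measured compounds shown here, in a functional assay on OVCAR-3 cells (Homo sapiens) for antiproliferative activity, with a stated time of 48 h (a lower number here means that less compound is tolerated, a higher number that more compound is tolerated), compound 2 stands at the higher of the two numbers; the single step leading to it, an 11-fold higher number from compound 1 to compound 2 (1.06 log units; beyond the scatter), was large. Compound 3 `COc1ccc(C2CC(c3cc(Cl)c(C)cc3O)=NN2c2ccc(S(N)(=O)=O)cc2)c(OC)c1OC` differs from compound 2 by methoxy in place of hydrogen on an aromatic carbon. For the measured compounds named here, no measured step bears directly on this change: the one step recorded exchanges the whole aryl group, which is a different kind of change. With nothing comparable to go on, no move beyond the scatter is expected, so the estimated step is a 1.0-fold higher number from compound 2 to compound 3 (0.01 log units; within the scatter). Compound 3 is therefore expected to give 80000 nM, within 30000 nM to 250000 nM.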

Compound 3, concentration lethal to 50% of the cells: 7690 nM
For compound 3 the middle estimate is 10-fold (1.02 log units) above the measured one, and the stated range ends above it.
By their numbers in this assay, from the lowest: compounds 1 and 3 (each within the scatter of the next); then compound 2.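

In this assay, methoxy on the aromatic carbon ortho to a large group and ortho to a methoxy group, turning 3,4-dimethoxyphenyl into 2,3,4-trimethoxyphenyl, gives a 10-fold lower number from compound 2 to compound 3 (1.00 log units; beyond the scatter), so this one carbon of the aryl group is sensitive to a small addition. Against the 2-chlorophenyl of compound 1, the trimethoxy aryl group is not told apart: a 1.1-fold higher number from compound 1 to compound 3 (0.06 log units; within the scatter). No measurement at hand explains the shift.

Open, from the compounds shown here alone, is whether methoxy on this carbon has the same effect without the 3,4-dimethoxy pattern. Also open, going by these compounds, is whether ethoxy, hydroxyl or an amine there gives a similar number.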